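Notes on an amide aryl swap in a sulfonamide series

This account rests on a few compounds, and the source may have more. Where it says the series, first, only, none or still open, it means among the compounds named here.

Compound 1 `COc1ccc(NS(=O)(=O)c2ccc(NC(=O)c3ccc(Cl)cc3Cl)cc2)cc1` is recorded as "not determined" (no result reported) in a functional assay on HEK293 cells for agonist activity at probable G-protein coupled receptor 27 (Homo sapiens), read by a luciferase reporter and beta-arrestin recruitment, with a stated time of 10 min (a higher number here means a larger maximal response, a lower number a smaller maximal response), so it gives no point of comparison. Among the compounds with values here, compound 2 `Cc1cc(Cl)ccc1C(=O)Nc1ccc(S(=O)(=O)Nc2ccccc2)cc1` gives 123% in this assay; this is the only number so far, and compound 2 therefore stands alone, with nothing to rank it against. Compound 3 `O=C(Nc1ccc(S(=O)(=O)Nc2ccccc2)cc1)c1ccc(Cl)nc1F` has not yet been measured. It differs from compound 2 in a single place on the amide carbonyl: 6-chloro-2-fluoropyridin-3-yl in place of 4-chloro-2-methylphenyl on a carbonyl carbon. Within the data shown here, no step between two measured compounds exists, so the effect of this kind of change is not anchored by any measured pair. In this assay the expected step is a number 18 percentage points lower from compound 2 to compound 3 (beyond the scatter), modest and downward, about at the edge of the usual scatter rather than clearly beyond it. For compound 3 the estimated value in this assay is 105%, with a range from 60% to 135%.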

Compound 3, largest response reached (Emax), in percent of the reference or control that the assay uses: 78%
For compound 3 the middle estimate is 27 percentage points above the measured one, within the range that was stated.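

Within the data shown here, the carbonyl position is not silent in this assay: replacing 4-chloro-2-methylphenyl with 6-chloro-2-fluoropyridin-3-yl gives a large step of a number 45 percentage points lower from compound 2 to compound 3 (beyond the scatter), the first measured pair. The two groups have the same heavy-atom count, so this pair shows that the maximal response can change substantially without a change in that count. No measurement at hand bears on the reason for the fall.

A single pair cannot separate the contributions of the ring nitrogen, the fluorine and the methyl group, as all three differ at once. Also open, from the compounds shown here alone, is how the response would change with a simple phenyl, a cyclohexyl group or a carboxylic acid-bearing ring on this carbonyl carbon.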